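The compounds below may be only part of what the source reports. "The series", "measured", "known", "first", "only" and "open" are said of these compounds alone.

Among the measured compounds shown here, the three compounds measured so far share one core and each carries an amino group. Compound 1 `Cc1cc(-c2nc3cc(F)c(F)cc3s2)ccc1N` and compound 2 `Nc1ccc(-c2nc3ccc(F)cc3s2)cc1Cl` bear one further substituent on the ring that holds the amino group, whereas compound 3 `Nc1ccc(-c2nc3cc(F)ccc3s2)cc1` carries none there. In a functional assay on MCF7 cells (Breast, Homo sapiens) for inhibition (on this read-out lower numbers stand for stronger inhibition of growth and higher numbers for weaker inhibition of growth), compound 1 reaches only the limit of the measurement, < 10 nM. Compound 2 also shows in this assay nothing but a limit, < 10 nM. Compound 3 gives in this assay a limit as well, < 10 nM. For the measured compounds named here, compound 2 therefore stands exactly where its two companions stand, at the limit of < 10 nM in this assay, at which 3 of the 3 values shown sit, so no order among the three can be read from the numbers, and no step between measured compounds exists to lean on.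

Compound 4 `Cc1cc(-c2nc3ccc(F)cc3s2)ccc1N` is the unmeasured partner of compound 2. The change is methyl in place of chloro on an aromatic carbon. Since compound 2 already rests at the limit of < 10 nM in this assay, at which 3 of the 3 values shown sit, a gain cannot be registered, and only a loss larger than the scatter could become visible as a number. Compound 4 is expected in this assay to give about 6 nM, within a range of 2 nM to 15 nM. The step that this estimate means, a step that the limit leaves unreadable from compound 2 to compound 4, is expected to stay within the scatter, most likely again as a limit rather than a number.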

Compound 4, concentration for 50% growth inhibition: < 10 nM
Compound 4 was reported as a limit; the forecaster's own chance of this, stated with the estimate: 70%; the middle value is on the limit's open side.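

In this assay compound 4 gives only a limit, < 10 nM. No step from compound 2 or compound 1 to compound 4 can be read, because all of these compounds rest at the same place: the limit of < 10 nM in this assay, at which 4 of the 4 values shown sit. The compounds shown leave open whether compound 1, compound 2, compound 3 and compound 4 differ at all in inhibition of growth.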